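Ester chain swap at the cytotoxicity limit

The source may report more compounds than this note shows. Statements on the series, on what has been measured and on what is new or still open speak of the compounds shown alone.

In an ADME assay on HOS cells (Homo sapiens) for cytotoxicity, read by luminescence and ATP content, with a stated time of 48 h (on this read-out lower numbers stand for higher toxicity in this test and higher numbers for lower toxicity in this test), compound 1 (`COC(=O)CCc1cnc2c(c1)c(N)c(C(=O)NCc1ccc(F)cc1F)c(=O)n2O`), bearing 2-(methoxycarbonyl)ethyl, gives > 250000 nM as a limit and not a number. Compound 2 (`O=C(NCc1ccc(F)cc1F)c1c(NCCO)c2cc(CCCCCO)cnc2n(O)c1=O`) gives > 250000 nM as a limit too. Compound 3 (`CC(=O)OCCCCCc1cnc2c(c1)c(NCCO)c(C(=O)NCc1ccc(F)cc1F)c(=O)n2O`), bearing 5-acetoxypentyl, gives > 100000 nM as a limit as well, so it has no number of its own and stands with the other two at a limit of the assay.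

Compound 4 (`COC(=O)CCc1cnc2c(c1)c(NCCO)c(C(=O)NCc1ccc(F)cc1F)c(=O)n2O`) departs from compound 3 by methoxycarbonyl in place of 3-acetoxypropyl on a saturated chain carbon, two bonds along the chain from an aromatic carbon with methoxycarbonyl in place of 3-acetoxypropyl on a saturated chain carbon, two bonds along the chain from an aromatic carbon.

Within the data shown here, the one measured step bearing on this chain is a step that the two limits leave unreadable from compound 2 to compound 3 and it offers no size to carry over. The expected change is a step that the limit leaves unreadable from compound 3 to compound 4 and no shift beyond the scatter is expected in either direction in this assay for this swap. Compound 4 is estimated at 220000 nM with an expected range of 90000 nM to 300000 nM and will probably read as a limit too.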

Compound 4, half-maximal cytotoxic concentration: > 250000 nM
Compound 4 ended at the assay's limit; the forecaster's own chance of this, stated with the estimate: 85%; middle value at least 1.1-fold (0.05 log units) from the limit.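

Among these compounds, compound 4, like compound 1, compound 2 and compound 3, reads only as a limit in this assay, and no step to compound 4 from any of them can be read. The compounds shown leave open whether any of these chain changes alters the half-maximal cytotoxic concentration at all.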